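The source may hold more compounds than are shown below. What is called first, only, known or untested is meant among the compounds shown, and "the series" means these compounds.

Of the compounds shown here, three that share one core have been tested in an ADME assay on the whole organism (muscle tissue) for activation, with Mus musculus as the target, in the rotarod test, with a stated time of 30 min; on this read-out lower numbers stand for an effect already at smaller amounts and higher numbers for an effect only at larger amounts of compound: compound 1 (`O=C1NC(=O)N(/N=C/c2ccc(-c3ccc(Cl)c(Cl)c3)o2)C1O`), compound 2 (`O=C1NC(=O)N(/N=C/c2ccc(-c3ccc(Cl)cc3)o2)C1O`) and compound 3 (`N#Cc1ccc(-c2ccc(/C=N/N3C(=O)NC(=O)C3O)o2)cc1`). Compound 1 gives 10 mg/kg. Compound 2 gives 63 mg/kg. Compound 3 gives 96 mg/kg, a number within the scatter of compound 2 and larger than that of compound 1.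

The next structure, compound 4 (`CC(=O)Nc1ccc(-c2ccc(/C=N/N3C(=O)NC(=O)C3O)o2)cc1`), differs from compound 3 in a single place: acetamido in place of cyano on an aromatic carbon. It carries acetamido in place of cyano on an aromatic carbon, para to a large group.

Among the measured compounds shown here, two measured steps bear on this change. The nearer one is a 1.5-fold higher number from compound 2 to compound 3 (0.18 log units; within the scatter), cyano in place of chloro on an aromatic carbon, since it brings in the group that now leaves, and it stays within the scatter. The other, a 6.3-fold higher number from compound 1 to compound 2 (0.80 log units; beyond the scatter), hydrogen in place of chloro on an aromatic carbon, goes beyond the scatter, so one substitution in this small set can move the number clearly. Neither step involves acetamido, and the data offer no direct guide to it. No step beyond the scatter is therefore expected in this assay, though the uncertainty remains wide. The expected outcome is a 1.2-fold lower number from compound 3 to compound 4 (0.08 log units; within the scatter). For compound 4 the estimate is 80 mg/kg, with an expected range of 25 mg/kg to 200 mg/kg.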

Compound 4, dose for half-maximal effect: > 1000 mg/kg
Compound 4: no number, only a limit; the forecaster's own chance of this, stated with the estimate: 10%; middle value at least 12-fold (1.09 log units) from the limit.
By their numbers in this assay, from the lowest: compound 1; then compounds 2 and 3 (each within the scatter of the next). At a limit, above all of these: compound 4.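

In this assay compound 4 gives no number, only a limit, > 1000 mg/kg. The aromatic carbon para to a large group therefore proves far more sensitive to its substituent than the exchange of chloro for cyano alone suggested: acetamido in place of cyano gives an at least 10-fold higher number from compound 3 to compound 4 (1.01 log units; beyond the scatter), and acetamido in place of chloro gives an at least 15-fold higher number from compound 2 to compound 4 (1.20 log units; beyond the scatter), both large steps beyond the scatter, whereas the step between chloro and cyano stayed within it. Both steps fix only the smallest possible size of the change, because compound 4 stands at a limit: the limit of > 1000 mg/kg in this assay, at which 1 of the 4 values shown sits.

The compounds shown leave open whether the step follows the hydrogen-bond donor that acetamido brings in or its larger count of heavy atoms, as the change introduces both at once. They also leave open whether an amine or a carboxylic acid on this aromatic carbon would stay within the scatter of chloro and cyano or would instead reach a limit like acetamido.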